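From compound 3 to compound 4: a phenyl swap

The compounds below may be only part of what the source reports. "The series", "measured", "known", "first", "only" and "open" are said of these compounds alone.

Measured so far in an ADME assay on Huh-7 cells (Homo sapiens) for cytotoxicity, read by MTT assay, with a stated time of 4 h, at 37 degrees C; a higher number here means that more compound is tolerated, a lower number that less compound is tolerated
compound 1 `COCCn1c(=O)c(-c2c(Cl)cccc2Cl)cc2c(N)nc(Nc3ccccc3)nc21` (241000 nM)
compound 2 `CCCOCCOc1nc(N)nc2c1cc(-c1c(Cl)cccc1Cl)c(=O)n2C` (50100 nM)
compound 3 `Nc1nc(Nc2ccccc2)nc2[nH]c(=O)c(-c3c(F)cccc3F)cc12` (2400 nM)

Compound 3 gives the lowest number of the three in this assay and lies beyond the scatter from both other compounds. Compound 2 is its nearest neighbour and compound 1 its furthest. Compound 4 `Nc1nc(Nc2ccccc2)nc2[nH]c(=O)c(-c3ccccc3)cc12` has not been measured. It carries phenyl in place of 2,6-difluorophenyl on an aromatic carbon and otherwise matches compound 3.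

Going by the values given here, no measured pair isolates this change, since compound 1 and compound 2 each differ from compound 3 in more than one place. The expectation therefore rests on little. Compound 3 at 2400 nM sits at the low end of this small set, while compound 2 at 50100 nM and compound 1 at 241000 nM stand far higher. A move toward higher numbers thus seems more likely than a further fall, though a result within the scatter of compound 3 remains possible. The expected step of a 2.9-fold higher number from compound 3 to compound 4 (0.46 log units; beyond the scatter) is a moderate rise in this assay and carries wide uncertainty. For compound 4 the estimated value is 7000 nM with an expected range from 1500 nM to 40000 nM in this read-out.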

Compound 4, half-maximal cytotoxic concentration: 13800 nM
The estimate for compound 4 lay 2.0-fold (0.29 log units) below the measured number; the range from low to high includes it.
By their numbers in this assay, from the lowest: compound 3; then compound 4; then compound 2; then compound 1.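

In this assay, going by these compounds alone, phenyl in place of 2,6-difluorophenyl on an aromatic carbon gives a 5.8-fold higher number from compound 3 to compound 4 (0.76 log units; beyond the scatter), the only step in this set that isolates a single place. The position is therefore not silent: the group shrinks from 8 to 6 heavy atoms, with its 2 fluorine atoms gone and its count of hydrogen-bond donors, hydrogen-bond acceptors and net charge unchanged, yet more compound is tolerated without them. No measurement at hand accounts for this step.

On these data alone, it remains open whether a single fluorine on the phenyl ring, or a methoxy group, an amine or a carboxylic acid there, would keep the number near compound 4, return it toward compound 3 or carry it elsewhere. Compound 1 and compound 2 each differ from compound 4 in more than one place, so their higher numbers cannot be assigned to this position, and whether the same step holds on their scaffolds also stays unsettled.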